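The source may hold more compounds than are shown below. What is called first, only, known or untested is meant among the compounds shown, and "the series" means these compounds.

In an in vivo ADME assay on the whole organism (strain Sprague-Dawley) for pharmacokinetics, with Rattus norvegicus as the target, at a dose of 1 mg/kg by the intravenous route (on this read-out higher numbers stand for fast clearance and lower numbers for slow clearance), compound 1 `COc1ccc(CNC(=O)c2c(C)nc3cc(C)ccn23)cc1` gives 28 mL/min/kg. Compound 2 `COc1cccc(CNC(=O)c2c(C)nc3cc(C)ccn23)c1` gives 43 mL/min/kg in this assay. Among the compounds with values here, these two numbers lie within the scatter of each other, so neither compound can be ranked against the other, and compound 1 stands together with the only other measured compound.

The unmeasured compound 3 `Cc1ccn2c(C(=O)NCc3ccc(Cl)cc3)c(C)nc2c1` keeps the core of compound 1 and alters a single group: chloro in place of methoxy on an aromatic carbon. In words, this is chloro in place of methoxy on an aromatic carbon, para to a large group.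

Within the data shown here, no measured pair here shows what this swap does in this assay, so the data give no direct guide to the size or direction of the step. The expectation is therefore no shift beyond the scatter, and the best anchor is compound 1 itself at 28 mL/min/kg. The estimated change is small, a 1.1-fold lower number from compound 1 to compound 3 (0.03 log units; within the scatter), and it stays within the scatter. The expected clearance of compound 3 is 26 mL/min/kg, with an estimated range from 13 mL/min/kg to 50 mL/min/kg.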

Compound 3, clearance: 51 mL/min/kg
Compound 3: middle estimate off by 2.0-fold (0.29 log units), on the low side, and the stated range ends below it.
By their numbers in this assay, from the lowest: compounds 1, 2 and 3 (each within the scatter of the next).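

Within the data shown here, the first measured step at this position is the swap of methoxy for chloro on an aromatic carbon, para to a large group, and in this assay it gives a 1.8-fold higher number from compound 1 to compound 3 (0.26 log units; within the scatter). This step lies within the usual scatter of repeated measurements, so this single pair shows no clearance difference that can be told apart from noise, even though the oxygen of the methoxy is gone and the position now carries a single chlorine atom. Nothing measured here explains why the number for compound 3 came out as it did, and no separate data bear on the mechanism of clearance for either compound.

The compounds shown leave open whether any group on this aromatic carbon can move clearance beyond the scatter, for instance fluoro, a nitrile, an amine or a carboxylic acid. Among these compounds, they also leave open whether the swap of methoxy for chloro would read the same way on a core other than the one shared by compound 1 and compound 3.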